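Urea-linked series: diethylamino replaces piperidinylmethyl

The source may hold more compounds than are shown below. What is called first, only, known or untested is meant among the compounds shown, and "the series" means these compounds.

Measured so far:
compound 1 `O=C(Nc1ccc(CN2CCCCC2)cc1)Nc1ccc2ncnc(Nc3cccc(C(F)(F)F)c3)c2c1` — 1550 nM
compound 2 `C[C@@H](Nc1ncnc2ccc(NC(=O)Nc3ccc(CN4CCN(C)CC4)cc3)cc12)c1ccccc1` — > 10000 nM
compound 3 `O=C(Nc1cccc(CN2CCCCC2)c1)Nc1ccc2ncnc(Nc3cccc(C(F)(F)F)c3)c2c1` — 1330 nM

In a functional assay on A-431 cells (Homo sapiens) for antiproliferative activity, read by MTT assay, with a stated time of 72 h (on this read-out higher numbers stand for weaker inhibition and lower numbers for stronger inhibition), compound 1 gives 1550 nM. Compound 3 `O=C(Nc1cccc(CN2CCCCC2)c1)Nc1ccc2ncnc(Nc3cccc(C(F)(F)F)c3)c2c1`, which carries the (piperidin-1-yl)methyl on another carbon of the same ring, gives 1330 nM in this assay; the two numbers lie within the scatter of each other, so compound 1 and compound 3 are read as one level. Compound 2 `C[C@@H](Nc1ncnc2ccc(NC(=O)Nc3ccc(CN4CCN(C)CC4)cc3)cc12)c1ccccc1` gives > 10000 nM in this assay, which is a limit and not a number (the limit of > 10000 nM in this assay, at which 1 of the 3 values shown sits). Compound 2 differs from compound 1 in two places at once, so its result says nothing about either change alone.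

Compound 4 `CCN(CC)c1ccc(NC(=O)Nc2ccc3ncnc(Nc4cccc(C(F)(F)F)c4)c3c2)cc1` is not yet measured. Its difference from compound 1: diethylamino in place of (piperidin-1-yl)methyl on an aromatic carbon. Among the measured compounds shown here, no measured pair in the set isolates this change. For the measured compounds named here, the only comparison available, compound 1 against compound 3, shows that moving the (piperidin-1-yl)methyl on that ring leaves the number within the scatter. Removing the ring and the methylene entirely is a larger change, and the expectation is a modest step, if any, toward a weaker number: a 1.6-fold higher number from compound 1 to compound 4 (0.21 log units; within the scatter) is the estimated step from compound 1 to compound 4. Compound 4 is expected to give about 2500 nM in this assay, with a range from 800 nM to 8000 nM.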

Compound 4, half-maximal inhibitory concentration: 6460 nM
Compound 4: middle estimate off by 2.6-fold (0.41 log units), on the low side; the measured number falls inside the stated range.
By their numbers in this assay, from the lowest: compounds 3 and 1 (each within the scatter of the next); then compound 4. At a limit, above all of these: compound 2.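

In this assay, diethylamino in place of (piperidin-1-yl)methyl on this aromatic carbon, para to a large group, gives a 4.2-fold higher number from compound 1 to compound 4 (0.62 log units; beyond the scatter). Among the compounds shown here, this is the first single change that separates two compounds beyond the scatter: compound 1 and compound 3, which differ only in where the (piperidin-1-yl)methyl sits on the ring, remain within the scatter of each other, so the identity of the group registers here where the shift in its place on the ring did not. No measured property in the set accounts for this step.

The change removes the piperidine ring and the methylene together, so the step cannot be assigned to either one alone; diethylaminomethyl or piperidin-1-yl at the same carbon would separate the two contributions. Also open, from the compounds shown here alone, is whether another ring on the methylene, such as morpholin-4-yl, keeps the number at the level of compound 1 in a molecule that otherwise matches it, and whether diethylamino behaves the same way on the other ring carbon occupied in compound 3.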